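The source may report more compounds than this note shows. Statements on the series, on what has been measured and on what is new or still open speak of the compounds shown alone.

In a functional assay on A2780 cells (Homo sapiens) for antiproliferative activity, read by MTT assay, with a stated time of 48 h (a higher number here means a weaker inhibitor, a lower number a stronger inhibitor), compound 1 `COc1ccc2c(/C=C/C(=O)c3cc(OC)c(OC)c(SC)c3)c[nH]c2c1` gives 139 nM and compound 2 `COc1ccc2c(/C=C/C(=O)c3cc(OC)c(OC)c([N+](=O)[O-])c3)c[nH]c2c1` gives 742 nM, the higher of the two numbers. Compound 3 `COc1cc(C(=O)/C=C/c2c[nH]c3ccccc23)cc([N+](=O)[O-])c1OC` alters compound 2 in one place, with hydrogen in place of methoxy on an aromatic carbon. Among the measured compounds shown here, the only measured step, a 5.3-fold higher number from compound 1 to compound 2 (0.73 log units; beyond the scatter), changed a different group, so it offers a rough size and no direct precedent. A similarly modest rise is expected, though the direction remains uncertain, giving an expected step of a 2.4-fold higher number from compound 2 to compound 3 (0.38 log units; beyond the scatter). For compound 3, the estimated value is 1800 nM, with an expected range of 500 nM to 6000 nM.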

Compound 3, half-maximal inhibitory concentration: 1280 nM
Estimate against measurement, compound 3: 1.4-fold (0.15 log units) above, within the range that was stated.
By their numbers in this assay, from the lowest: compound 1; then compounds 2 and 3 (each within the scatter of the next).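

Hydrogen in place of methoxy on this aromatic carbon of the fused ring system gives a 1.7-fold higher number from compound 2 to compound 3 (0.24 log units; within the scatter) in this assay, so compound 2 and compound 3 cannot be told apart. Among the compounds shown here, the earlier step changed a different group, so this is the first reading at this position: here, the methoxy can go without a change beyond the scatter. Nothing measured here gives a reason for this result.
Going by these compounds, whether an amine or an ethoxy on this carbon would read the same remains open. So does whether losing the methoxy would matter as little with methylsulfanyl in place of the nitro.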